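Ethynyl for Iodo on a Nucleoside Core

The compounds below may be only part of what the source reports. "The series", "measured", "known", "first", "only" and "open" are said of these compounds alone.

Three nucleosides have so far been tested in a functional assay on HeLa S3 cells (Homo sapiens) for antiproliferative activity, read by XTT assay, with a stated time of 72 h; a lower number here means a stronger inhibitor, a higher number a weaker inhibitor. Compound 1 `Nc1nc(N)c2c(-c3ccsc3)cn([C@@H]3O[C@H](CO)[C@@H](O)[C@H]3O)c2n1` gives only a limit there, > 20000 nM. Compound 2 `COc1nc(N)nc2c1c(-c1cc3ccccc3o1)cn2[C@@H]1O[C@H](CO)[C@@H](O)[C@H]1O` likewise gives only a limit, > 20000 nM. Within the data shown here, compound 3 `COc1ncnc2c1c(I)cn2[C@@H]1O[C@H](CO)[C@@H](O)[C@H]1O` is the one compound with an actual number, 14300 nM. The two other results sit at the assay limit, (the limit of > 20000 nM in this assay, at which 2 of the 3 values shown sit), so compound 3 stands alone as the single measured point. Compound 4 `C#Cc1cn([C@@H]2O[C@H](CO)[C@@H](O)[C@H]2O)c2ncnc(OC)c12` has not yet been measured. It differs from compound 3 in one place: ethynyl in place of iodo on an aromatic carbon. Among the measured compounds shown here, no step between two measured compounds is available to gauge this exchange, so the expectation rests on compound 3 by itself. A modest step toward stronger inhibition is expected, a 2.4-fold lower number from compound 3 to compound 4 (0.38 log units; beyond the scatter), although a shift no larger than the usual scatter would not be surprising. Compound 4 is accordingly expected to give about 6000 nM in this assay, with a range from 1500 nM to 20000 nM.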

Compound 4, half-maximal inhibitory concentration: 1730 nM
Compound 4: middle estimate off by 3.5-fold (0.54 log units), on the high side; measured number inside the range.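

In this assay, among these compounds, ethynyl in place of iodo on this aromatic carbon gives an 8.3-fold lower number from compound 3 to compound 4 (0.92 log units; beyond the scatter), the first step that can be read at this position. It shows that the number responds to the group held here, even though the exchange swaps one iodine for two carbons and brings in no hydrogen-bond donor or acceptor. Compounds 1 and 2 carry other groups at this carbon, but they also differ from compound 4 elsewhere and give only limits, so they offered no such reading: the limit of > 20000 nM in this assay, at which 2 of the 4 values shown sit.

A single step on one core does not tell what in the ethynyl group produces the shift, and the data give no cause for it. From the compounds shown here alone, whether a longer alkyne chain, a nitrile or an amine at this carbon would go beyond compound 4 remains open.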